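A few compounds are considered here, and "the series" means these few. Any claim that something is new, unique, unknown or untested is made for them only; others in the source may bear on it.

Working notes on the series: compound 1 (`CCOC(=O)c1nn(-c2ccc(Cl)cc2)c(-c2ccc(C)cc2)c1CNC(C)(C)C`), compound 2 (`CC(C)(C)NCc1c(C(=O)O)nn(-c2ccc(Cl)cc2)c1-c1ccccc1`) and the unmeasured compound 3 (`Cc1ccc(-c2c(CNC(C)(C)C)c(C(=O)O)nn2-c2ccc(Cl)cc2)cc1`), followed in a functional assay on K562 cells (Homo sapiens) for inhibition, read by sulforhodamine B assay, with a stated time of 48 h; on this read-out lower numbers stand for stronger inhibition of growth and higher numbers for weaker inhibition of growth. In this assay compound 1 gives 106000 nM; > 542000 nM (2 entries), which is not one single number. Compound 2 gives > 652000 nM in this assay, and this is a limit and not a number. Compound 2 therefore has no single value, and its position is known only from that limit.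

The step to compound 3 is small: methyl in place of hydrogen on an aromatic carbon, turning phenyl into 4-methylphenyl. Within the data shown here, no pair of measured compounds sizes this change directly. Compound 1 already carries the 4-methylphenyl group and gives 106000 nM; > 542000 nM (2 entries), so weak growth inhibition is expected to persist. No step beyond the scatter is expected in this assay, and another limit is the likeliest report. The expected change is an at least 1.3-fold lower number from compound 2 to compound 3 (0.11 log units; that floor lies within the scatter). For compound 3 the estimated value is 500000 nM, with an expected range of 150000 nM to 900000 nM.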

Compound 3, concentration for 50% growth inhibition: > 629000 nM
Compound 3 was reported as a limit; the forecaster's own chance of this, stated with the estimate: 75%; middle value at least 1.2-fold (0.09 log units) away from the limit.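

In this assay compound 2 and compound 3 are both reported only as limits, and no step can be read from one to the other. The compounds shown leave open whether turning phenyl into 4-methylphenyl changes growth inhibition at all, and in which direction, as neither compound has a single number.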